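Triazole series: ethoxy in place of ethylsulfanyl at compound 1

The source may report more compounds than this note shows. Statements on the series, on what has been measured and on what is new or still open speak of the compounds shown alone.

Measured compounds in a functional assay on the whole organism (strain NMRI) with Mus musculus as the target, with a stated time of 60 min, at a dose of 10 mg/kg by the intraperitoneal route; on this read-out higher numbers stand for a stronger effect at the one dose given and lower numbers for a weaker effect:
- compound 1 `CCSc1nnc(Cc2ccc(Cl)cc2Oc2ccccc2Cl)[nH]1`: 140%
- compound 2 `CCSc1nnc(Cc2ccc(Cl)cc2Oc2ccccc2F)[nH]1`: 144%
- compound 3 `CCOc1nnc(Cc2ccccc2Oc2ccccc2)[nH]1`: 126%

Compound 1 stands second highest of the three numbers in this assay. Its nearest neighbour is compound 2, reached by fluoro in place of chloro on an aromatic carbon, with a number 4 percentage points higher from compound 1 to compound 2 (within the scatter). The furthest is compound 3, which carries ethoxy on the shared core and no chloro on either outer ring; compound 3 gives 126%, lower than compound 1 by more than the scatter.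

Compound 4 `CCOc1nnc(Cc2ccc(Cl)cc2Oc2ccccc2Cl)[nH]1` has not yet been measured. It differs from compound 1 by ethoxy in place of ethylsulfanyl on an aromatic carbon.

Going by the values given here, no measured step covers this exchange alone. Among the compounds with values here, the only step recorded, from compound 1 to compound 2, touches a different position and lies within the scatter. Within the data shown here, compound 3 is the sole ethoxy member, but it differs from compound 1 in more than one place, so its lower number cannot be credited to the ethoxy group by itself. The expectation is therefore a small drop at most, likely within the scatter.

Compound 4 is expected to give 130%, in the range 112% to 148%. The estimated step is a number 10 percentage points lower from compound 1 to compound 4 (within the scatter).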

Compound 4, a percentage reported as activity, at one dose (the size of the read-out at that dose, not a potency): 122%
Estimate against measurement, compound 4: 8 percentage points above; the measured number falls inside the stated range.
By their numbers in this assay, from the lowest: compounds 4 and 3 (each within the scatter of the next); then compounds 1 and 2 (each within the scatter of the next).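

In this assay, the exchange of ethylsulfanyl for ethoxy, taken alone on the aromatic carbon between two ring nitrogen atoms, gives a number 18 percentage points lower from compound 1 to compound 4 (beyond the scatter), so this position does respond to the change in a single atom. Going by these compounds alone, the two groups match in heavy-atom count and in hydrogen-bond donor and acceptor counts, which leaves sulfur against oxygen as the counted difference, and the step is the first single change to lie beyond the scatter. The data shown offer no explanation for the loss on going to ethoxy.

Still open, on these data alone, is whether the same exchange gives a step of similar size with the fluoro group of compound 2 on the outer ring. Also open, as far as these compounds go, is how a longer chain, such as butylsulfanyl, or an amine would read at this position.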